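Selenium for sulfur on the benzylic chain: two cores

The source may report more compounds than this note shows. Statements on the series, on what has been measured and on what is new or still open speak of the compounds shown alone.

Compound 1 `Cc1noc(C)c1CSC#N` in a functional assay on MCF7 cells (Homo sapiens) for cytotoxicity, read by MTT assay, with a stated time of 72 h (on this read-out higher numbers stand for weaker inhibition of growth and lower numbers for stronger inhibition of growth), gives 4800 nM. Compound 2 `Cc1noc(C)c1C[Se]C#N` carries the change a group of 3 heavy atoms (1 carbon, 1 nitrogen, 1 selenium; no ring) in place of a group of 3 heavy atoms (1 carbon, 1 nitrogen, 1 sulfur; no ring), on a saturated chain carbon bound to an aromatic carbon and in this assay compound 2 gives 2200 nM, a step of a 2.2-fold lower number from compound 1 to compound 2 (0.34 log units; beyond the scatter). On a second core, compound 3 `N#CSCc1ccc(-n2cccc2)cc1` in this assay gives 8200 nM; the difference between the core of compound 3 and the core of compound 1 is not broken down here. Compound 4 `N#C[Se]Cc1ccc(-n2cccc2)cc1` is not yet measured and differs from compound 3 by a group of 3 heavy atoms (1 carbon, 1 nitrogen, 1 selenium; no ring) in place of a group of 3 heavy atoms (1 carbon, 1 nitrogen, 1 sulfur; no ring), on a saturated chain carbon bound to an aromatic carbon, the same change as from compound 1 to compound 2, at the same place, a saturated chain carbon bound to an aromatic carbon. As far as these compounds go, with a single prior instance, the expectation for the step from compound 3 to compound 4 is put at a 2.2-fold lower number from compound 3 to compound 4 (0.33 log units; beyond the scatter), resting on a 2.2-fold lower number from compound 1 to compound 2 (0.34 log units; beyond the scatter); whether the step carries over between cores is untested. Compound 4 is therefore estimated in this assay at 3800 nM, with a range from 2000 nM to 7500 nM.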

Compound 4, concentration for 50% growth inhibition: 2400 nM
For compound 4 the middle estimate is 1.6-fold (0.20 log units) above the measured one; low and high end bracket the measured number.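

In this assay, putting the selenium group in place of cyanosulfanyl on the saturated chain carbon bound to an aromatic carbon gives a 3.4-fold lower number from compound 3 to compound 4 (0.53 log units; beyond the scatter). Set beside the earlier step, the change goes the same way on both cores, and the two steps do not differ in size: the same change on two cores in this assay, a 2.2-fold lower number (0.34 log units; beyond the scatter) from compound 1 to compound 2 and a 3.4-fold lower number (0.53 log units; beyond the scatter) from compound 3 to compound 4, 1.6-fold (0.19 log units) apart, within the scatter of two such steps. This shows that the change carried over between these two cores in this one read-out, but two cores are too few to support a rule for the series, and the numbers do not tell why the selenium compounds give lower values.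

Still open, as far as these compounds go, is whether the step holds on a core bearing an amine or a carboxylic acid, or with a longer chain carrying the cyanosulfanyl group and its selenium counterpart. Also open, from the compounds shown here alone, is which part of the core matters, since the difference between the core of compound 1 and the core of compound 3 is not broken down here.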